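Dropping a chloro from a diaryl urea series

A few compounds are considered here, and "the series" means these few. Any claim that something is new, unique, unknown or untested is made for them only; others in the source may bear on it.

The two measured compounds share a pyrazole-bearing urea core. Compound 1 `O=C(Nc1cccc(-n2cc(-c3ccncc3)c(-c3cc(O)cc(Cl)c3)n2)c1)Nc1ccc(Cl)c(Cl)c1` carries a phenol on one aryl group and a dichlorophenyl urea; in a functional assay on Malme-3M cells (Homo sapiens) for inhibition, read by sulforhodamine B assay, with a stated time of 48 h, tested at 10 uM (on this read-out higher numbers stand for a weaker effect at the one concentration tested and lower numbers for a stronger effect), compound 1 gives -35.1%. Compound 2 `COc1cc(Cl)cc(-c2nn(-c3cccc(NC(=O)Nc4ccc(Cl)c(C(F)(F)F)c4)c3)cc2-c2ccncc2)c1` has a methoxy in place of that phenol and a 4-chloro-3-(trifluoromethyl)phenyl urea; in this assay compound 2 gives -19.8%. On these two numbers compound 2 stands highest, its nearest neighbour being compound 1, whose number lies lower by a gap beyond the scatter, so compound 2 shows the weaker effect of the pair.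

Compound 3 `COc1cc(Cl)cc(-c2nn(-c3cccc(NC(=O)Nc4cccc(C(F)(F)F)c4)c3)cc2-c2ccncc2)c1` differs from compound 2 in one place: hydrogen in place of chloro on an aromatic carbon. Within the data shown here, no comparable step between measured compounds exists here, so the size of this step is not known from the data. The author expects a step from compound 2 to compound 3 of a number 9.8 percentage points higher from compound 2 to compound 3 (within the scatter), a small move toward a weaker effect that may well fall within the scatter. Compound 3 is therefore expected to give about -10% in this assay, in a range from -32% to 12%.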

Compound 3, a percentage reported as activity, at one concentration (the size of the read-out at that concentration, not a potency): -16.6%
The estimate for compound 3 lay 6.6 percentage points above the measured number; low and high end bracket the measured number.
By their numbers in this assay, from the lowest: compound 1; then compounds 2 and 3 (each within the scatter of the next).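

Going from 4-chloro-3-(trifluoromethyl)phenyl to 3-(trifluoromethyl)phenyl, in this assay the urea series now has its first one-place step, a number 3.2 percentage points higher from compound 2 to compound 3 (within the scatter) with all else held fixed. Compound 1 and compound 2 differ in more than one place and could not speak to any single position, whereas this pair shows that, at one concentration, hydrogen can stand in place of chloro on this aromatic carbon, ortho to a trifluoromethyl group and para to a large group, without a step beyond the scatter. Nothing measured here bears on why this step has the size it does.

The compounds shown leave open whether another group on this carbon, such as a nitrile, an amine or a carboxylic acid, would give a step beyond the scatter. They also leave open whether the same exchange of chloro for hydrogen would read alike with the trifluoromethyl group replaced by a methyl group, or with the phenol of compound 1 in place of the methoxy.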